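Chain lengthening in two series of cytotoxic compounds

The compounds below may be only part of what the source reports. "The series", "measured", "known", "first", "only" and "open" are said of these compounds alone.

Compound 1 `CCC1C(=O)N(CCCCCCOc2ccc(Cl)cc2)/C(=N\C#N)N1c1ccncc1` and compound 2 `CCC1C(=O)N(CCCCCCCOc2ccc(Cl)cc2)/C(=N\C#N)N1c1ccncc1` share one core and differ by a single change: (4-chlorophenoxy)methyl in place of 4-chlorophenoxy on a saturated chain carbon, six bonds along the chain from an amide-type nitrogen in a ring. In a functional assay on HepG2 cells (Homo sapiens) for cytotoxicity (a lower number here means a stronger inhibitor, a higher number a weaker inhibitor), compound 1 gives 4350 nM, while compound 2 gives 3450 nM, a step of a 1.3-fold lower number from compound 1 to compound 2 (0.10 log units; within the scatter). Compound 3 `N#C/N=C1\N(CCCCCCOc2ccc(Cl)cc2)C(=O)CCN1c1ccncc1` carries a different core; the difference between the two cores is not broken down here. In this assay compound 3 gives 344 nM, the lowest of the three numbers. Compound 4 `N#C/N=C1\N(CCCCCCCOc2ccc(Cl)cc2)C(=O)CCN1c1ccncc1` is built from compound 3 by the same change, at the same place: (4-chlorophenoxy)methyl in place of 4-chlorophenoxy on a saturated chain carbon, six bonds along the chain from an amide-type nitrogen in a ring. A step of about a 1.2-fold lower number from compound 3 to compound 4 (0.07 log units; within the scatter) is expected, because the earlier step of a 1.3-fold lower number from compound 1 to compound 2 (0.10 log units; within the scatter) stayed within the scatter, so little movement is foreseen. Compound 4 is therefore estimated at 290 nM in this assay, with a likely range from 120 nM to 700 nM.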

Compound 4, half-maximal inhibitory concentration: 4000 nM
The estimate for compound 4 lay 14-fold (1.14 log units) below the measured number; the measured number lies above the stated range.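

The same change, (4-chlorophenoxy)methyl in place of 4-chlorophenoxy, gives in this assay a 12-fold higher number from compound 3 to compound 4 (1.07 log units; beyond the scatter), so its effect on one core does not carry over to the other: the same change on two cores in this assay, a 1.3-fold lower number (0.10 log units; within the scatter) from compound 1 to compound 2 and a 12-fold higher number (1.07 log units; beyond the scatter) from compound 3 to compound 4, 15-fold (1.17 log units) apart, beyond the scatter of two such steps

A step seen on the core of compound 1 therefore cannot safely be used to predict the step on the core of compound 3. These results do not show why the two cores respond differently, and a single pair on each core gives no general rule.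

Still open, going by these compounds, is how a shorter chain or a longer chain, such as 2-(4-chlorophenoxy)ethyl, would behave on each core. Also open, on these data alone, is whether an unsubstituted phenoxy group at the chain end would show the same split between the cores.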